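A few compounds are considered here, and "the series" means these few. Any claim that something is new, unique, unknown or untested is made for them only; others in the source may bear on it.

Within the data shown here, only two compounds have numbers so far in a functional assay on HepG2 cells (Homo sapiens) for cytotoxicity, with a stated time of 24 h (on this read-out lower numbers stand for stronger inhibition and higher numbers for weaker inhibition), and they differ in more than one place. Compound 1 `COc1cc(Cl)ccc1C(=O)Nc1cc(Cl)ccc1O` gives 87000 nM while compound 2 `COc1cc(Cl)ccc1C(=S)Nc1ccc(Cl)cc1O` gives 5110 nM as the lower number of the pair. That gap lies beyond the usual scatter of repeated measurements, so compound 2 stands as the stronger of the two, yet the pair cannot show what any single change does.

Compound 3 `COc1cc(Cl)ccc1C(=S)Nc1cc(Cl)c(Cl)cc1O` has not been measured yet and departs from compound 2 in one place only, counted as chloro in place of hydrogen on an aromatic carbon with the rest of the structure untouched. Put simply, chloro replaces hydrogen on an aromatic carbon, ortho to a chloro group and para to a hydroxy group. Among the measured compounds shown here, no measured pair isolates a change like this one, so any forecast is loose. A modest shift toward a lower number is expected, one that may stay within the scatter. The estimated move is a 1.7-fold lower number from compound 2 to compound 3 (0.23 log units; within the scatter) and it could turn out smaller. In this assay the estimate for compound 3 is 3000 nM with 1000 nM to 9000 nM as the expected range.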

Compound 3, half-maximal inhibitory concentration: 3160 nM
Compound 3: middle estimate off by 1.1-fold (0.02 log units), on the low side; the range from low to high includes it.
By their numbers in this assay, from the lowest: compounds 3 and 2 (each within the scatter of the next); then compound 1.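

Among these compounds, this is the first change in this assay that can be read in a single place: putting chloro in place of hydrogen on the aromatic carbon ortho to a chloro group and para to a hydroxy group gives a 1.6-fold lower number from compound 2 to compound 3 (0.21 log units; within the scatter). Within this pair, the added chlorine therefore leaves the read-out indistinguishable from that of the hydrogen-bearing compound, something the earlier pair could not show because its two members differ in more than one place. No supporting data are available to explain this outcome.

As far as these compounds go, it remains open whether this aromatic carbon would behave the same way with a different kind of group, such as an amine, a carboxylic acid or a longer alkyl chain, since one chloro group says little about other substituents there. Also unresolved is what each separate difference between compound 1 and compound 2 contributes, including the change between the carbonyl and its sulfur counterpart. No pair shown isolates any one of those differences.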